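Swapping furan-2-yl for thiophen-2-yl in compound 2

A few compounds are considered here, and "the series" means these few. Any claim that something is new, unique, unknown or untested is made for them only; others in the source may bear on it.

Compound 1 `OC[C@H]1O[C@@H](n2cc(F)c3c(-c4ccccc4)ncnc32)[C@H](O)[C@@H]1O`: 3100 nM
Compound 2 `OC[C@H]1O[C@@H](n2cc(F)c3c(-c4ccco4)ncnc32)[C@H](O)[C@@H]1O`: 1400 nM

In a functional assay on CCRF-CEM cells (Homo sapiens) for cytotoxicity, read by XTT assay, with a stated time of 3 days (a lower number here means a stronger inhibitor, a higher number a weaker inhibitor), compound 2 holds the lower of the two numbers. Compound 3 `OC[C@H]1O[C@@H](n2cc(F)c3c(-c4cccs4)ncnc32)[C@H](O)[C@@H]1O` differs from it in one group: thiophen-2-yl in place of furan-2-yl on an aromatic carbon. For the measured compounds named here, the only measured step, a 2.2-fold lower number from compound 1 to compound 2 (0.35 log units; beyond the scatter), was modest and swapped phenyl for furan-2-yl, a different change from this one. The leaving and entering groups match in size and ring type, so no step beyond the scatter is expected in this assay. The estimated step is no change at the digits printed from compound 2 to compound 3 (within the scatter). For compound 3 the expected value is 1400 nM, with an estimated range of 500 nM to 4000 nM.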

Compound 3, half-maximal inhibitory concentration: 270 nM
For compound 3 the middle estimate is 5.2-fold (0.71 log units) above the measured one, outside the stated range (below it).
By their numbers in this assay, from the lowest: compound 3; then compound 2; then compound 1.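

In this assay, this aromatic carbon proves sensitive to a single ring atom: sulfur in place of oxygen gives a 5.2-fold lower number from compound 2 to compound 3 (0.71 log units; beyond the scatter), so matching size and ring type do not make these two groups interchangeable here. Thiophen-2-yl also improves on phenyl, with an 11-fold lower number from compound 1 to compound 3 (1.06 log units; beyond the scatter), the largest step among these compounds. Nothing available explains this gain. Still open, from the compounds shown here alone, is whether thiophen-3-yl or an amine on this carbon would lower the number further. Going by these compounds, whether this order holds in other cell types also remains unknown.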